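The source may hold more compounds than are shown below. What is called first, only, known or untested is meant among the compounds shown, and "the series" means these compounds.

Compound 2 `CCCCCc1ccc(-c2cn(C[C@H](O)[C@H]3OC(=O)C(OCc4ccccc4)=C3OCc3ccccc3)nn2)cc1` is the reference point of the series. Within the data shown here, in a functional assay on SW-620 cells (Homo sapiens) for antiproliferative activity, read by MTT assay, with a stated time of 72 h (on this read-out higher numbers stand for weaker inhibition and lower numbers for stronger inhibition), compound 2 gives 12200 nM, the only number among the three measured values. Compound 1 `Cc1ccc(-c2cn(C/C=C3\OC(=O)C(OCc4ccccc4)=C3OCc3ccccc3)nn2)cc1` reaches only a limit of the assay in this assay, > 100000 nM. Compound 3 `COc1ccccc1-c1cn(C/C=C2\OC(=O)C(OCc3ccccc3)=C2OCc2ccccc2)nn1` likewise stops at a limit in this assay, > 100000 nM. The step that the two limits leave unreadable from compound 1 to compound 3 is therefore not readable, as both ends sit at the limit of > 100000 nM in this assay, at which 2 of the 3 values shown sit. Compound 4 `O=C1O[C@H]([C@@H](O)Cn2cc(-c3cc(F)cc(F)c3)nn2)C(OCc2ccccc2)=C1OCc1ccccc1` differs from compound 2 by 3,5-difluorophenyl in place of 4-pentylphenyl on an aromatic carbon. Among the measured compounds shown here, no measured step covers this change; the only other change on the same aromatic carbon yields no size, so nothing in the set says how large a move to expect or in which direction. What remains is the number of compound 2 in this assay as an anchor, with a wide range around it. Compound 4 is expected to sit near that anchor or somewhat weaker, the step of a 2.0-fold higher number from compound 2 to compound 4 (0.31 log units; beyond the scatter) being an estimate without a measured precedent. Compound 4 is estimated at 25000 nM in this assay, with a range from 8000 nM to 100000 nM.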

Compound 4, half-maximal inhibitory concentration: > 100000 nM
Compound 4 gave a limit, no number; the forecaster's own chance of this, stated with the estimate: 35%; middle value at least 4.0-fold (0.60 log units) away from the limit.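

Among these compounds, this is the first step of readable size at this aromatic carbon: in this assay, 3,5-difluorophenyl in place of 4-pentylphenyl gives an at least 8.1-fold higher number from compound 2 to compound 4 (0.91 log units; beyond the scatter). The position therefore does not tolerate every aryl group, and within this pair the measurable antiproliferative activity stays with 4-pentylphenyl. Compound 4 is a limit and not a number, so the step has a lower bound only, and compound 2 remains the only compound with a number: the limit of > 100000 nM in this assay, at which 3 of the 4 values shown sit.

The pair changes the chain and the ring fluorines together, so it cannot separate the loss of the pentyl chain from the entry of the two fluorine atoms. Also open, on these data alone, is how an unsubstituted phenyl, a 4-heptylphenyl with its longer chain, or a 4-aminophenyl would read at this carbon.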